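Benzylsulfanyl for hexyloxy on the aromatic carbon: compound 3

The compounds below may be only part of what the source reports. "The series", "measured", "known", "first", "only" and "open" are said of these compounds alone.

Measured so far in an assay on cells for antagonist activity at transient receptor potential cation channel subfamily V member 1 (Homo sapiens), read by FLIPR and calcium flux, with a stated time of 6 min; on this read-out lower numbers stand for stronger inhibition and higher numbers for weaker inhibition:
compound 1 `CC(C(=O)NCc1ccc(C(C)(C)C)nc1N1CCCC1)c1ccc(NS(C)(=O)=O)c(F)c1` gives 1.2 nM
compound 2 `CCCCCCOc1nc(C(C)(C)C)ccc1CNC(=O)C(C)c1ccc(NS(C)(=O)=O)c(F)c1` gives 2.7 nM

Within the data shown here, compound 2 stands at the higher of the two numbers in this assay; the only measured step is a 2.3-fold higher number from compound 1 to compound 2 (0.35 log units; beyond the scatter). Compound 3 `CC(C(=O)NCc1ccc(C(C)(C)C)nc1SCc1ccccc1)c1ccc(NS(C)(=O)=O)c(F)c1` arises from compound 2 by benzylsulfanyl in place of hexyloxy on an aromatic carbon. Among the measured compounds shown here, that measured step concerns a different exchange on an aromatic carbon and bears only loosely on this one; no step covers the exchange of hexyloxy for benzylsulfanyl. With a single modest reference step, a step of no more than similar size is expected, direction open. Compound 3 is expected to give 3.5 nM, between 1.2 nM and 12 nM. The expected step is a 1.3-fold higher number from compound 2 to compound 3 (0.11 log units; within the scatter).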

Compound 3, inhibition constant: 4 nM
Compound 3: middle estimate off by 1.1-fold (0.06 log units), on the low side; the measured number falls inside the stated range.
By their numbers in this assay, from the lowest: compound 1; then compounds 2 and 3 (each within the scatter of the next).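

In this assay, benzylsulfanyl in place of hexyloxy on the aromatic carbon next to the ring nitrogen gives a 1.5-fold higher number from compound 2 to compound 3 (0.17 log units; within the scatter), so this position does not separate these two groups, although only benzylsulfanyl carries an aromatic ring. Against pyrrolidin-1-yl, the same group gives a 3.3-fold higher number from compound 1 to compound 3 (0.52 log units; beyond the scatter), leaving compound 1 apart from both compound 2 and compound 3. No available evidence accounts for either step. Open, on these data alone, is whether piperidin-1-yl or dimethylamino at this position would match compound 1, and whether a methoxy group would match compound 2.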